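The compounds below may be only part of what the source reports. "The series", "measured", "known", "first", "only" and "open" are said of these compounds alone.

Working notes on the series.

Compound 2 `CC(C)(C)c1ccc(-c2cn(C/C=C3\OC(=O)C(OCc4ccccc4)=C3OCc3ccccc3)nn2)cc1` is measured in a functional assay on U-937 cells (Homo sapiens) for antiproliferative activity, read by MTT assay, with a stated time of 24 h; a higher number here means a weaker inhibitor, a lower number a stronger inhibitor. For compound 2 the read-out is a limit, > 100000 nM, not a number. Compound 1 `O=C1O/C(=C\Cn2cc(Cc3ccccc3)nn2)C(OCc2ccccc2)=C1OCc1ccccc1` likewise gives only a limit in this assay, > 100000 nM. The step from compound 1 to compound 2, a 4-(tert-butyl)phenyl in place of benzyl on an aromatic carbon, cannot be sized, a step that the two limits leave unreadable from compound 1 to compound 2, since both ends sit at the same limit, (the limit of > 100000 nM in this assay, at which 2 of the 3 values shown sit). Within the data shown here, compound 3 `O=C1NC(O)(CCn2cc(-c3ccccc3)nn2)C(OCc2ccccc2)=C1OCc1ccccc1`, on a different core, is the only member with a number in this assay and gives 21500 nM; no single-point step links it to compound 2.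

Compound 4 `Cc1ccc(-c2cn(C/C=C3\OC(=O)C(OCc4ccccc4)=C3OCc3ccccc3)nn2)cc1` differs from compound 2 by methyl in place of tert-butyl on an aromatic carbon, a methyl in place of tert-butyl on an aromatic carbon. Among the measured compounds shown here, no measured step bears directly on this change, and the only neighbouring step is itself unreadable. With compound 2 at the limit, compound 4 is expected to remain near it, an expected step of a number no higher from compound 2 to compound 4 (the limit leaves the size open). The estimate for compound 4 in this assay is 100000 nM, expected within 30000 nM to 300000 nM.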

Compound 4, half-maximal inhibitory concentration: > 100000 nM
Compound 4 ended at the assay's limit; the forecaster's own chance of this, stated with the estimate: 70%; the middle value sits exactly at the limit.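

No new step can be read in this assay: compound 1, compound 2 and compound 4 each give only a limit, so the steps among them cannot be sized: the limit of > 100000 nM in this assay, at which 3 of the 4 values shown sit.

The compounds shown leave open whether methyl and tert-butyl differ at all in this assay.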